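Sulfonyl aryl change: 2-methylphenyl to 4-methoxyphenyl

This account rests on a few compounds, and the source may have more. Where it says the series, first, only, none or still open, it means among the compounds named here.

Among the measured compounds shown here, in a functional assay on HeLa cells (Homo sapiens) for cytotoxicity, read by sulforhodamine B assay (a higher number here means a weaker inhibitor, a lower number a stronger inhibitor), compound 2 (`Cc1ccccc1S(=O)(=O)NC(C1=CC(=O)c2c(O)ccc(O)c2C1=O)C(C)C`) gives 790 nM, the lower of the two numbers so far. Compound 1 (`Cc1ccc(S(=O)(=O)NC(C2=CC(=O)c3c(O)ccc(O)c3C2=O)C(C)C)cc1`) gives 4850 nM. Compound 3 (`COc1ccc(S(=O)(=O)NC(C2=CC(=O)c3c(O)ccc(O)c3C2=O)C(C)C)cc1`) carries 4-methoxyphenyl in place of 2-methylphenyl on a sulfonyl sulfur. For the measured compounds named here, one measured step bears on this: a 6.1-fold lower number from compound 1 to compound 2 (0.79 log units; beyond the scatter), with 2-methylphenyl in place of 4-methylphenyl. Compound 3 gives up that 2-methylphenyl, so part of that step is expected to be lost. The expected change is a 3.8-fold higher number from compound 2 to compound 3 (0.58 log units; beyond the scatter), towards a higher number. Compound 3 is estimated at 3000 nM, with an expected range of 1000 nM to 9000 nM.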

Compound 3, half-maximal inhibitory concentration: 8950 nM
The estimate for compound 3 lay 3.0-fold (0.47 log units) below the measured number; measured number inside the range.
By their numbers in this assay, from the lowest: compound 2; then compounds 1 and 3 (each within the scatter of the next).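

In this assay the 4-methoxyphenyl group does not hold the level of the 2-methylphenyl group: an 11-fold higher number from compound 2 to compound 3 (1.05 log units; beyond the scatter). Methoxy in place of methyl on an aromatic carbon does not separate the two compounds, with a 1.8-fold higher number from compound 1 to compound 3 (0.27 log units; within the scatter), so among these three sulfonyl aryl groups only the 2-methylphenyl of compound 2 stands apart. No measurement at hand explains this difference.

Open, on these data alone, is whether an unsubstituted phenyl on a sulfonyl sulfur would sit nearer compound 2 or compound 3. Also open, as far as these compounds go, is how a pyridyl ring or an aminophenyl group would read at this place.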